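Swapping the benzyl sulfanyl arm on a sulfonylguanidine core

This account rests on a few compounds, and the source may have more. Where it says the series, first, only, none or still open, it means among the compounds named here.

Compound 1 `Cc1ccc(CSc2cc(Cl)c(C)cc2S(=O)(=O)/N=C(\N)n2nc(C)cc2-c2ccccc2)cc1` gives 89000 nM in a functional assay on MCF7 cells (Homo sapiens) for cytotoxicity, read by MTT assay, with a stated time of 72 h (a higher number here means a weaker inhibitor, a lower number a stronger inhibitor), a number that lies within the usual scatter of compound 2 `Cc1cc(S(=O)(=O)/N=C(\N)n2nccc2-c2ccccc2)c(SCc2cccc3ccccc23)cc1Cl` with 58000 nM and of compound 3 `Cc1cc(S(=O)(=O)/N=C(\N)n2nccc2-c2ccccc2)c(SCc2ccc(Cl)cc2)cc1Cl` with 75000 nM. Compound 4 `Cc1cc(-c2ccccc2)n(/C(N)=N/S(=O)(=O)c2cc(C)c(Cl)cc2SCc2ccccc2C(F)(F)F)n1` differs from compound 1 only at the benzyl sulfanyl arm: 2-(trifluoromethyl)phenyl in place of 4-methylphenyl on a saturated chain carbon bound to a sulfur. Among the compounds with values here, the one measured step at this position, a 1.3-fold higher number from compound 2 to compound 3 (0.11 log units; within the scatter), did not move the number beyond the scatter, and no other step touches this arm. The change from 4-methylbenzyl to 2-(trifluoromethyl)benzyl is therefore expected to give no step beyond the scatter, a 1.1-fold lower number from compound 1 to compound 4 (0.05 log units; within the scatter). Compound 4 is accordingly estimated at 80000 nM, within a range of 35000 nM to 180000 nM.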

Compound 4, half-maximal inhibitory concentration: 101000 nM
Estimate against measurement, compound 4: 1.3-fold (0.10 log units) below; the measured number falls inside the stated range.
By their numbers in this assay, from the lowest: compounds 2, 3, 1 and 4 (each within the scatter of the next).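

Within the data shown here, replacing 4-methylphenyl with 2-(trifluoromethyl)phenyl on a saturated chain carbon bound to a sulfur gives a 1.1-fold higher number from compound 1 to compound 4 (0.05 log units; within the scatter) in this assay on the core of compound 1, whereas the only earlier step at this arm stood on the core of compound 2. The arm therefore stays within the scatter on both cores, even with a group carrying three fluorine atoms. No evidence at hand bears on this result. Every arm shown ends in an aromatic carbon ring. On these data alone, whether an amine, a carboxylic acid or a longer chain there would move the number beyond the scatter remains open.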